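A few compounds are considered here, and "the series" means these few. Any claim that something is new, unique, unknown or untested is made for them only; others in the source may bear on it.

Two compounds of the series have numbers in a functional assay on HT-29 cells (Homo sapiens) for cytotoxicity, read by MTT assay, with a stated time of 72 h; a higher number here means a weaker inhibitor, a lower number a stronger inhibitor. Compound 1 `COc1cc2c(Oc3ccc(NC(=O)c4cn(-c5ccccc5)nn4)cc3F)ccnc2cc1OCCCN1CCCC1` gives 180 nM in this assay, the lowest of the two numbers. Compound 2 `COc1cc2c(Oc3ccc(NC(=O)c4cn(-c5ccccc5C)nn4)cc3F)ccnc2cc1OCCCN1CCCC1` gives 1200 nM in this assay. Among the compounds with values here, the only step between measured compounds, a 6.7-fold higher number from compound 1 to compound 2 (0.82 log units; beyond the scatter), comes from a methyl in place of hydrogen on an aromatic carbon at the opposite end of the shared core from the chain considered here.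

Compound 3 `COc1cc2c(Oc3ccc(NC(=O)c4cn(-c5ccccc5)nn4)cc3F)ccnc2cc1OCCCN1CCCCC1` is not yet measured. It differs from compound 1 by piperidin-1-yl in place of pyrrolidin-1-yl on a saturated chain carbon, three bonds along the chain from an oxygen on an aromatic ring. Within the data shown here, no measured step touches the ring at the end of this chain; the step from compound 1 to compound 2 sits elsewhere and shows only that a single small change can move the number in this assay by a modest amount. For the exchange of pyrrolidin-1-yl for piperidin-1-yl there is no comparison in the data, so the expected step from compound 1 to compound 3 in this assay is none beyond the scatter, no change at the digits printed from compound 1 to compound 3 (within the scatter). Compound 3 is therefore estimated at 180 nM, with a range of 80 nM to 450 nM.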

Compound 3, half-maximal inhibitory concentration: 180 nM
Estimate against measurement, compound 3: no gap at the digits printed; low and high end bracket the measured number.
By their numbers in this assay, from the lowest: compounds 1 and 3 (each within the scatter of the next); then compound 2.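

In this assay, within the data shown here, the first reading at the ring at the end of the 3-(pyrrolidin-1-yl)propyl chain gives no change at the digits printed from compound 1 to compound 3 (within the scatter) for piperidin-1-yl in place of pyrrolidin-1-yl. At this position, then, the one six-membered non-aromatic ring in place of the one five-membered non-aromatic ring leaves the number where it stood, whereas the methyl step elsewhere on the molecule gives a 6.7-fold higher number from compound 1 to compound 2 (0.82 log units; beyond the scatter). No measurement among the data bears on why the exchange leaves the cytotoxicity number in place.

The compounds shown leave open whether this holds beyond the two saturated rings compared here, for example with morpholin-4-yl or an open-chain dimethylamino group at the end of the chain, or with a shorter or longer chain than propyl in place of the one carrying these rings. They also leave open whether piperidin-1-yl behaves the same way on the methyl-bearing compound 2, since the exchange is read only on the core of compound 1 and only in this assay.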